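From Ethoxy to Propoxy on a Shared Core

The source may report more compounds than this note shows. Statements on the series, on what has been measured and on what is new or still open speak of the compounds shown alone.

For the measured compounds named here, in a functional assay on HepG2 cells (Homo sapiens) for antiproliferative activity, read by sulforhodamine B assay, with a stated time of 3 days (on this read-out higher numbers stand for an effect only at larger amounts of compound and lower numbers for an effect already at smaller amounts), compound 2 `CCCC1=C(OCC)C(CCC)(CCC)C(=O)/C(=C(O)\C=C\c2ccccc2)C1=O` gives 11.2 uM as the only number available. Compound 1 `CCCC1=C(OC)C(CCC)(CCC)C(=O)/C(=C(O)\C=C\c2ccccc2)C1=O` has the entry "not determined" (no result reported) and offers no comparison. Compound 3 `CCCOC1=C(CCC)C(=O)/C(=C(O)/C=C/c2ccccc2)C(=O)C1(CCC)CCC` differs from compound 2 by methyl in place of hydrogen on a saturated chain carbon, two bonds along the chain from an oxygen on an unsaturated carbon and so turns ethoxy to propoxy, with methyl in place of hydrogen on a saturated chain carbon. Going by the values given here, no measured pair shows what such a change does in this assay so, with compound 2 at 11.2 uM as the only anchor, no step beyond the scatter is expected in either direction. The estimated change a 1.1-fold lower number from compound 2 to compound 3 (0.05 log units; within the scatter) is expected to stay small. Compound 3 is expected at 10 uM within an estimated range of 4 uM to 25 uM as a working estimate.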

Compound 3, concentration for half-maximal effect: 8.3 uM
For compound 3 the middle estimate is 1.2-fold (0.08 log units) above the measured one; measured number inside the range.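

In this assay, for the compounds shown here, the change from ethoxy to propoxy gives a 1.3-fold lower number from compound 2 to compound 3 (0.13 log units; within the scatter) and so supplies the first measured pair for this place. On a saturated chain carbon, two bonds along the chain from an oxygen on an unsaturated carbon, methyl in place of hydrogen moves the number by no more than the usual scatter. Nothing at hand offers an explanation of this result.

Going by these compounds alone, no step involving compound 1, the methoxy member, can be read. Going by these compounds, whether a longer chain such as butoxy, or an amine at the chain end, would stay within the scatter remains open.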